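Aryl exchange at the double-bonded chain carbon

The source may report more compounds than this note shows. Statements on the series, on what has been measured and on what is new or still open speak of the compounds shown alone.

Values in a functional assay on SW480 cells (Homo sapiens) for antiproliferative activity, read by sulforhodamine B assay, with a stated time of 48 h; on this read-out lower numbers stand for stronger inhibition and higher numbers for weaker inhibition:
- compound 1 `COc1cccc(/C=C/C(=O)C(=Cc2ccc(F)cc2)C(=O)/C=C/c2cccc(OC)c2OC)c1OC`: 1040 nM
- compound 2 `COc1cc(OC)c(C=C(C(=O)/C=C/c2cccc(OC)c2OC)C(=O)/C=C/c2cccc(OC)c2OC)c(OC)c1`: 840 nM

Compound 2, at 840 nM, lies within the scatter of compound 1, at 1040 nM. Next in line is compound 3 `COc1cc(C=C(C(=O)/C=C/c2cccc(OC)c2OC)C(=O)/C=C/c2cccc(OC)c2OC)cc(Br)c1O`, and the change is 3-bromo-4-hydroxy-5-methoxyphenyl in place of 2,4,6-trimethoxyphenyl on a double-bonded chain carbon bound to a double-bonded chain carbon.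

Going by the values given here, one measured step bears on this, an exchange of aryl groups at the same place: a 1.2-fold lower number from compound 1 to compound 2 (0.09 log units; within the scatter). Among the compounds with values here, that step is small, but it is the only evidence. Within the data shown here, no measured compound carries bromine or a hydroxy group, so the range has to stay wide. No step beyond the scatter is expected in this assay, and neither direction is favoured. The expected step is a 1.1-fold higher number from compound 2 to compound 3 (0.03 log units; within the scatter). The estimate for compound 3 is 900 nM, with an expected range of 350 nM to 2300 nM.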

Compound 3, half-maximal inhibitory concentration: 260 nM
Compound 3: the middle estimate sits 3.5-fold (0.54 log units) above what was measured; measured number below the stated range.
By their numbers in this assay, from the lowest: compound 3; then compounds 2 and 1 (each within the scatter of the next).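

In this assay, the aryl group on a double-bonded chain carbon bound to a double-bonded chain carbon can now be seen to shift the number beyond the scatter: 3-bromo-4-hydroxy-5-methoxyphenyl gives a step against both earlier aryl groups (a 3.2-fold lower number from compound 2 to compound 3 (0.51 log units; beyond the scatter); a 4.0-fold lower number from compound 1 to compound 3 (0.60 log units; beyond the scatter)). The exchange of 4-fluorophenyl for 2,4,6-trimethoxyphenyl stayed within the scatter, so the earlier pair gave no sign that this position responds to the aryl group. No independent measurement bears on why the number falls with this change.

Bromine and the hydroxy group enter together, so the compounds shown cannot assign the step to either one or to their combination. Going by these compounds, how an amine or a carboxylic acid in place of the hydroxy group would read in this assay also remains open.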